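This account rests on a few compounds, and the source may have more. Where it says the series, first, only, none or still open, it means among the compounds named here.

In a functional assay on A549 cells (Homo sapiens) for inhibition, read by CCK-8 assay, with a stated time of 72 h, tested at 2 uM (a higher number here means more inhibition of growth at the concentration tested, a lower number less inhibition of growth), compound 3 (`Cc1ccc(SCc2ccc(C(=O)Nc3ccccc3N)cc2)cc1`) gives 40.5%. Where compound 3 carries methyl, compound 1 (`COc1ccc(SCc2ccc(C(=O)Nc3ccccc3N)cc2)cc1`) carries methoxy and gives 45.7%. The data show a number 5.2 percentage points lower from compound 1 to compound 3 (within the scatter), so these two cannot be told apart. Compound 2 (`CCc1ccc(SCc2ccc(C(=O)Nc3ccccc3N)cc2)cc1`), which carries ethyl at that place, gives 53.6%. Against compound 3 this is the only clear gap: the data show a number 13.1 percentage points lower from compound 2 to compound 3 (beyond the scatter). The remaining pair also stays close, with a number 7.9 percentage points higher from compound 1 to compound 2 (within the scatter).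

Compound 4 (`CC(C)(C)c1ccc(SCc2ccc(C(=O)Nc3ccccc3N)cc2)cc1`) makes one change to compound 3: tert-butyl in place of methyl on an aromatic carbon. Put simply, this is tert-butyl in place of methyl on an aromatic carbon. The most relevant evidence is the pair of compound 2 and compound 3, where the ethyl compound stands higher, with a number 13.1 percentage points lower from compound 2 to compound 3 (beyond the scatter). That is a single modest step, and compound 1 adds little, since a number 5.2 percentage points lower from compound 1 to compound 3 (within the scatter) shows no clear change. Within the data shown here, no measured compound yet carries a group like tert-butyl, so a rise of about that modest size is expected, with real uncertainty. The expected change is a number 11.5 percentage points higher from compound 3 to compound 4 (beyond the scatter). For compound 4 the estimated value is 52%, with an expected range from 38% to 66%.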

Compound 4, percent growth inhibition at one concentration: 38.6%
Compound 4: middle estimate off by 13.4 percentage points, on the high side; the range from low to high includes it.
By their numbers in this assay, from the lowest: compounds 4, 3, 1 and 2 (each within the scatter of the next, the first and the last beyond it).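

Replacing methyl, a single carbon, with tert-butyl, four carbons, on this aromatic carbon gives no readable change in this assay, with a number 1.9 percentage points lower from compound 3 to compound 4 (within the scatter). The clear gain of compound 2 over compound 3 therefore does not extend into a general rule that more carbon at this position gives more growth inhibition, and compound 4 is the compound that goes against such a rule, with a number 15 percentage points lower from compound 2 to compound 4 (beyond the scatter). Methoxy cannot be separated from tert-butyl either, with a number 7.1 percentage points lower from compound 1 to compound 4 (within the scatter), so ethyl stands clear of methyl and tert-butyl but not of methoxy.

Nothing in the data given explains why ethyl stands apart from these two groups at this position. Whether that higher level is special to ethyl remains open, as the compounds shown do not include propyl, isopropyl, or a polar group such as an amine or a carboxylic acid at this place.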